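Selenium-bearing quinazoline amines: cytotoxicity on breast cancer cells

This account rests on a few compounds, and the source may have more. Where it says the series, first, only, none or still open, it means among the compounds named here.

Measured so far:
compound 1 `C[Se]c1nc([Se]C)c2cccnc2n1`, "not determined" (no result reported) in a functional assay on MCF7 cells (Homo sapiens) for cytotoxicity, read by MTT assay, with a stated time of 72 h; on this read-out higher numbers stand for lower toxicity in this test and lower numbers for higher toxicity in this test
compound 2 `CCCCC[Se]c1nc(NCc2ccc(SC)cc2)c2ccccc2n1`, 95300 nM
compound 3 `CSc1ccc(CNc2nc([SeH])nc3ccccc23)cc1`, > 100000 nM

For compound 3 the value is a limit of the assay, not a number, and it sits at the limit of > 100000 nM in this assay, at which 1 of the 3 values shown sits. Going by the values given here, the single measured step, an at least 1.0-fold higher number from compound 2 to compound 3 (0.02 log units; that floor lies within the scatter), concerns the selenium substituent and lies within the scatter. Compound 4 `[SeH]c1nc(NCc2ccccc2)c2ccccc2n1` differs from compound 3 by hydrogen in place of methylsulfanyl on an aromatic carbon; no measured step touches that position, so nothing shown points to a change beyond the scatter. Compound 4 is therefore expected to stand near compound 3, with a number no higher from compound 3 to compound 4 (the limit leaves the size open), most likely again reported only as a limit. The estimate for compound 4 is 100000 nM, within 50000 nM to 300000 nM.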

Compound 4, concentration lethal to 50% of the cells: > 100000 nM
Compound 4 ended at the assay's limit (the forecaster's own chance of this, stated with the estimate: 70%); the middle value lies on the limit itself.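

No step can be read between compound 3 and compound 4, since both values are limits and not numbers: the limit of > 100000 nM in this assay, at which 2 of the 4 values shown sit. The compounds shown leave open whether hydrogen in place of methylsulfanyl on an aromatic carbon changes the read-out in this assay.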